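Chloro on the Adenine Core of a Branched Hydroxyalkyl Chain

A few compounds are considered here, and "the series" means these few. Any claim that something is new, unique, unknown or untested is made for them only; others in the source may bear on it.

The series rests on a shared core carrying a branched chain with a terminal hydroxyl. Compound 1 `CCCCCCCC(CCO)n1cnc2c(N)ncnc21` is the parent. Compound 2 `CCCCCCCC(CCO)n1cnc2c(N)nc(Cl)nc21` adds (chloro in place of hydrogen on an aromatic carbon). Compound 3 `CCCCCCCCC(CCO)n1cnc2c(N)ncnc21` differs from compound 1 by methyl in place of hydrogen on a saturated chain carbon, eight bonds along the chain from an aromatic nitrogen, and compound 4 `CCCCCCCCC(CCO)n1cnc2c(N)nc(Cl)nc21` carries both changes. In a functional assay on HCT-116 cells (Homo sapiens) for antiproliferative activity, read by MTT assay, with a stated time of 48 h (a lower number here means a stronger inhibitor, a higher number a weaker inhibitor), compound 1 gives only a limit, > 50000 nM. Compound 2 likewise gives only a limit in this assay, > 50000 nM. Compound 3 gives 11600 nM. The step of an at least 4.3-fold lower number from compound 1 to compound 3 (0.63 log units; beyond the scatter) is therefore real, while the step that the two limits leave unreadable from compound 1 to compound 2 cannot be read because of the limit of > 50000 nM in this assay, at which 2 of the 3 values shown sit. The change to compound 4, (chloro in place of hydrogen on an aromatic carbon), is the same change made from compound 1 to compound 2, at the same place. Since that earlier step is unreadable, the expectation for compound 4 rests on compound 3 alone and is estimated as roughly flat, a 1.3-fold higher number from compound 3 to compound 4 (0.11 log units; within the scatter). Compound 4 is expected to give about 15000 nM, between 5000 nM and 50000 nM.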

Compound 4, half-maximal inhibitory concentration: 21000 nM
Compound 4: the middle estimate sits 1.4-fold (0.15 log units) below what was measured; low and high end bracket the measured number.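

In this assay the chloro change on the core of compound 3 gives a 1.8-fold higher number from compound 3 to compound 4 (0.26 log units; within the scatter) so compound 3 and compound 4 cannot be told apart. The methyl change carried onto the chloro-bearing core gives an at least 2.3-fold lower number from compound 2 to compound 4 (0.37 log units; beyond the scatter) and it points the same way on both cores, though its size cannot be compared between them: the same change on two cores in this assay, an at least 4.3-fold lower number (0.63 log units; beyond the scatter) from compound 1 to compound 3 and an at least 2.3-fold lower number (0.37 log units; beyond the scatter) from compound 2 to compound 4; the limit leaves it open whether they differ
Whether the chloro change itself carries from one core to the other is not shown, since its step on the core of compound 1 cannot be read: the limit of > 50000 nM in this assay, at which 2 of the 4 values shown sit.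

The compounds shown leave open whether a longer chain would lower the number further. They also leave open how an amine in place of the chloro, or a carboxylic acid in place of the terminal hydroxyl, would read in this assay on this core.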